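Swapping Fluoro for Hydroxy: an Expected Cell Viability Value

This account rests on a few compounds, and the source may have more. Where it says the series, first, only, none or still open, it means among the compounds named here.

Two hydrazones built on one shared core have been tested in an ADME assay on J774 cells (Mus musculus) for cytotoxicity, read by MTT assay, with a stated time of 48 h, tested at 50 ug/mL; on this read-out higher numbers stand for a weaker effect at the one concentration tested and lower numbers for a stronger effect. Compound 1 `O=C(N/N=C/c1ccc(F)cc1)c1cnccn1` gives 78%, while compound 2 `O=C(N/N=C/c1ccccc1Br)c1cnccn1` gives 98%. Of these two numbers compound 1 stands lowest, and the value of compound 2 lies higher by a gap beyond the usual scatter.

Compound 3 `O=C(N/N=C/c1ccc(O)cc1)c1cnccn1` has not yet been measured in this assay. Relative to compound 1 it carries hydroxy in place of fluoro on an aromatic carbon. Going by the values given here, no measured pair of compounds shows this exchange, so its effect cannot be read from the data in hand. A step of modest size is expected, leaning if anything toward a weaker effect, though not clearly beyond the scatter; the estimated step is a number 7 percentage points higher from compound 1 to compound 3 (within the scatter). Compound 3 is thus expected to give about 85% in this assay, with a likely range from 65% to 100%.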

Compound 3, a percentage reported as activity, at one concentration (the size of the read-out at that concentration, not a potency): 100%
Estimate against measurement, compound 3: 15 percentage points below; measured number inside the range.
By their numbers in this assay, from the lowest: compound 1; then compounds 2 and 3 (each within the scatter of the next).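

In this assay, going by these compounds alone, the place on an aromatic carbon para to a large group proves sensitive to a single exchange: hydroxy in place of fluoro gives a number 22 percentage points higher from compound 1 to compound 3 (beyond the scatter) and so gives the first direct reading of a change at this position. The lower number of compound 1 can thus be tied to the fluoro at this place rather than to the shared core alone, since the two compounds differ nowhere else. No measurement at hand explains why the exchange has this effect.

The compounds shown leave open whether an amine, a methoxy group or a chlorine at this same place would read like the hydroxy or like the fluoro. They also leave open whether a carboxylic acid there would keep the number as high as the hydroxy does.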